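Cyano for Trifluoromethyl in a Cytotoxicity Comparison

The source may report more compounds than this note shows. Statements on the series, on what has been measured and on what is new or still open speak of the compounds shown alone.

Compound 2 `CC1=C2CC(C)(C)/C=C/C(=O)/C(C)=C\C3=C[C@H](C)C[C@]3(O2)[C@@]1(O)C(F)(F)F` and compound 3 `CC1=C2CC(C)(C)/C=C/C(=O)/C(C)=C\C3=C[C@H](C)C[C@]3(O2)[C@@]1(O)C#N` share one core, and compound 3 arises from compound 2 by cyano in place of trifluoromethyl on a saturated ring carbon. In an ADME assay on BJ cells (Homo sapiens) for cytotoxicity, read by CellTiter-Glo, with a stated time of 72 h (on this read-out lower numbers stand for an effect already at smaller amounts and higher numbers for an effect only at larger amounts of compound), compound 2 gives 26000 nM, and compound 3 gives 26000 nM; the step of no change at the digits printed from compound 2 to compound 3 (within the scatter). Compound 1 `C/C1=C/C2=C[C@H](C)C[C@@]23O[C@]2(CC(C)(C)C[C@@H]2[C@@]1(O)C(F)(F)F)[C@@H](C)C3=O` has a different core, and how the two cores differ is not broken down here. In this assay compound 1 gives 26000 nM. Compound 4 `C/C1=C/C2=C[C@H](C)C[C@@]23O[C@]2(CC(C)(C)C[C@@H]2[C@@]1(O)C#N)[C@@H](C)C3=O` is made from compound 1 by cyano in place of trifluoromethyl on a saturated ring carbon. This is the same kind of change as from compound 2 to compound 3, not the same: here the carbon belongs to an eight-membered ring in a system of four rings rather than a five-membered ring in a system of three rings. Because the step of no change at the digits printed from compound 2 to compound 3 (within the scatter), compound 4 is expected to give 26000 nM, between 13000 nM and 52000 nM, a step of no change at the digits printed from compound 1 to compound 4 (within the scatter).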

Compound 4, half-maximal effective concentration: 26000 nM
The estimate for compound 4 equals the measured number at the digits printed; the range from low to high includes it.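

In this assay, with cyano in place of trifluoromethyl on a saturated ring carbon, the step reads no change at the digits printed from compound 1 to compound 4 (within the scatter). Set beside the earlier case, the two cores give matching results for this change: the same change on two cores in this assay, no change at the digits printed (within the scatter) from compound 2 to compound 3 and no change at the digits printed (within the scatter) from compound 1 to compound 4, 1.0-fold (0.00 log units) apart, within the scatter of two such steps. This shows that the step agrees on these two cores in this one assay, but it does not show that it would agree on any further core or in any other read-out.

The compounds shown leave open how other groups on this saturated ring carbon, such as an amine or a carboxylic acid, would read in this assay. They also leave open whether such groups would give matching results on both cores.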